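Methoxy in Place of Amino on the Aryl Ketone

This account rests on a few compounds, and the source may have more. Where it says the series, first, only, none or still open, it means among the compounds named here.

Among the measured compounds shown here, compound 1 `COc1cc(-c2cc(/C=C/C(=O)c3ccc(N)cc3)[nH]n2)cc(OC)c1OC` is the stronger-looking of the two compounds measured so far in a functional assay on RXF 393 cells (Homo sapiens) for inhibition, read by sulforhodamine B assay, with a stated time of 48 h (a lower number here means a stronger inhibitor of growth, a higher number a weaker inhibitor of growth), where compound 1 gives 1350 nM, the lowest of the two numbers. Its companion, compound 2 `COc1ccc(-c2cc(/C=C/C(=O)c3ccc(N)cc3)[nH]n2)cc1OC`, gives 2150 nM in this assay, and the step of a 1.6-fold higher number from compound 1 to compound 2 (0.20 log units; within the scatter) concerns a group on a part of the shared core that is not touched by the change considered here.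

Compound 3 `COc1ccc(C(=O)/C=C/c2cc(-c3cc(OC)c(OC)c(OC)c3)n[nH]2)cc1` differs from compound 1 by methoxy in place of amino on an aromatic carbon, the group sitting on an aromatic carbon of a six-membered aromatic ring of carbon only, para to a large group. For the measured compounds named here, no measured step bears on this exchange; the only step available stays within the scatter and lies elsewhere. Compound 1 therefore serves as the only anchor. The step of a 1.5-fold higher number from compound 1 to compound 3 (0.17 log units; within the scatter) is expected to be small, in either direction. For compound 3 the estimate in this assay is 2000 nM, with a range from 600 nM to 7000 nM.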

Compound 3, concentration for 50% growth inhibition: 1270 nM
Compound 3: middle estimate off by 1.6-fold (0.20 log units), on the high side; the range from low to high includes it.
By their numbers in this assay, from the lowest: compounds 3, 1 and 2 (each within the scatter of the next).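

Among the compounds shown here, the first measurement at this position, on an aromatic carbon para to a large group, gives in this assay the step of a 1.1-fold lower number from compound 1 to compound 3 (0.03 log units; within the scatter), so the change from 4-aminophenyl to 4-methoxyphenyl cannot be told apart from no change at all. For compounds 1 and 3, then, a group counted with one hydrogen-bond donor and a group counted with none give numbers within the scatter of each other, even though the entering group has the larger count of heavy atoms. Nothing available explains why the two groups read alike.

The compounds shown leave open whether a carboxylic acid, a dimethylamino group or a longer chain such as butoxy at this position would also stay within the scatter. They also leave open whether the same exchange would read alike on the core of compound 2, which carries one methoxy group fewer.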